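A few compounds are considered here, and "the series" means these few. Any claim that something is new, unique, unknown or untested is made for them only; others in the source may bear on it.

In a functional assay on BT-474 cells (Homo sapiens) for antiproliferative activity, read by MTT assay, with a stated time of 72 h (on this read-out higher numbers stand for weaker inhibition and lower numbers for stronger inhibition), compound 1 `CC(Nc1ncnc2ncc(-c3cnn(C)c3)cc12)c1c(Cl)ccc(F)c1Cl` reaches only a limit rather than a number, > 100000 nM. Compound 1 thus sits at the limit of > 100000 nM in this assay, at which 1 of the 2 values shown sits. Compound 2 `Cn1cc(-c2ccc3ncnc(Nc4ccc(F)c(Cl)c4)c3c2)cn1` is the one compound with an actual number in this assay, where compound 2 gives 5260 nM; on the numbers shown it stands alone, with no second number to set beside it. Compound 3 `C#Cc1cccc(Nc2ncnc3ccc(-c4cnn(C)c4)cc23)c1` differs from compound 2 in one place: 3-ethynylphenyl in place of 3-chloro-4-fluorophenyl on a nitrogen on an aromatic ring, so that 3-ethynylphenyl replaces 3-chloro-4-fluorophenyl on a nitrogen on an aromatic ring whose other neighbours are aromatic carbon. Within the data shown here, no measured step between compounds is known here, so the size of this change cannot be read from any precedent. The step from compound 2 to compound 3 in this assay is expected to be a 1.2-fold lower number from compound 2 to compound 3 (0.07 log units; within the scatter), that is, nothing beyond the usual scatter. Compound 3 is accordingly estimated at 4500 nM, within a range from 1200 nM to 16000 nM.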

Compound 3, half-maximal inhibitory concentration: 5680 nM
Compound 3: middle estimate off by 1.3-fold (0.10 log units), on the low side; low and high end bracket the measured number.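

In this assay, among these compounds, the exchange of 3-chloro-4-fluorophenyl for 3-ethynylphenyl on a nitrogen on an aromatic ring gives a 1.1-fold higher number from compound 2 to compound 3 (0.03 log units; within the scatter) as the first measured step at this place, where the earlier compounds offered no pair to read. In this one pair, then, a phenyl ring carrying chlorine and fluorine and a phenyl ring carrying a triple bond cannot be told apart on this read-out, and the two groups also match in heavy-atom count. Nothing measured here bears on why the two groups read alike.

Going by these compounds, how the read-out would respond to an amine or a carboxylic acid on the phenyl ring, or to a longer chain in place of the ethynyl group, stays open. On these data alone, whether the same exchange reads alike on another core is also open.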